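The source may report more compounds than this note shows. Statements on the series, on what has been measured and on what is new or still open speak of the compounds shown alone.

Working notes on the series. In an ADME assay on Huh-7 cells (Homo sapiens) for cytotoxicity, read by MTT assay, with a stated time of 48 h (a higher number here means that more compound is tolerated, a lower number that less compound is tolerated), compound 1 `CN(C)CCCCN(C(=O)O)c1ccccc1Cn1nc(-c2ccc(F)cc2)c2ccccc2c1=O` gives 48500 nM, compound 2 `CCCCOC(=O)Nc1ccc(CN2N=C(c3ccc(F)cc3)C3C=CC=CC3C2=O)cc1` gives 19500 nM, and compound 3 `COc1ccc(-c2nn(Cc3ccc(NC(=O)OCCCCN(C)C)cc3)c(=O)c3ccccc23)cc1` gives 20300 nM. Among these three numbers compound 3 stands second highest; its nearest neighbour is compound 2, whose value lies within the usual scatter of it, while compound 1 sits furthest away with a higher number beyond the scatter. Compound 4 `CN(C)CCCCOC(=O)Nc1ccc(Cn2nc(-c3ccccc3C(F)(F)F)c3ccccc3c2=O)cc1` has not yet been measured. It differs from compound 3 in one place: 2-(trifluoromethyl)phenyl in place of 4-methoxyphenyl on an aromatic carbon. Among the compounds with values here, no pair of measured compounds differs by exactly this change, so the step has no precedent. The expected step from compound 3 to compound 4 in this assay is a 1.4-fold lower number from compound 3 to compound 4 (0.13 log units; within the scatter), a modest drop that may not exceed the scatter. Compound 4 is expected to give 15000 nM, with a range of 6000 nM to 40000 nM.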

Compound 4, half-maximal cytotoxic concentration: 35700 nM
Compound 4: middle estimate off by 2.4-fold (0.38 log units), on the low side, within the range that was stated.
By their numbers in this assay, from the lowest: compounds 2, 3, 4 and 1 (each within the scatter of the next, the first and the last beyond it).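

In this assay, the exchange at this aromatic carbon next to the ring nitrogen gives a 1.8-fold higher number from compound 3 to compound 4 (0.25 log units; within the scatter), the first step read at this position. Within the scatter, 2-(trifluoromethyl)phenyl and 4-methoxyphenyl cannot be told apart here, although the exchange alters both the substituent and where it sits on the phenyl ring. No measurement at hand offers an explanation for this step.

A single step cannot separate the substituent from its place on the ring, and 4-(trifluoromethyl)phenyl would bear on that. Going by these compounds, whether an amine or a carboxylic acid on this phenyl ring would produce a step beyond the scatter remains open.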